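Changing the chain end of compound 2

A few compounds are considered here, and "the series" means these few. Any claim that something is new, unique, unknown or untested is made for them only; others in the source may bear on it.

In an ADME assay on L02 cells (Homo sapiens) for cytotoxicity, read by MTT assay, with a stated time of 72 h (on this read-out higher numbers stand for weaker inhibition and lower numbers for stronger inhibition), compound 1 (`Nc1ncnc2c1c(-c1cnc3[nH]ccc3c1)nn2CCCCCCCCC(=O)NO`), which also ends in hydroxycarbamoyl, gives 35100 nM. Compound 2 (`CNC(=O)CCCCCCCn1nc(-c2ccc3oc(N)nc3c2)c2c(N)ncnc21`) gives 8040 nM, the lower of the two numbers, with the gap beyond the scatter. Compound 3 (`Nc1nc2cc(-c3nn(CCCCCCC(=O)NO)c4ncnc(N)c34)ccc2o1`) is still unmeasured. It differs from compound 2 by hydroxycarbamoyl in place of (methylcarbamoyl)methyl on a saturated chain carbon, six bonds along the chain from an aromatic nitrogen, with hydroxycarbamoyl in place of (methylcarbamoyl)methyl on a saturated chain carbon. Among the measured compounds shown here, no measured pair isolates this change, and the cores of the measured compounds differ. The expected change, a 1.2-fold higher number from compound 2 to compound 3 (0.09 log units; within the scatter), stays within the scatter in this assay. For compound 3 the estimate is 10000 nM, with an expected range of 2500 nM to 40000 nM.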

Compound 3, half-maximal inhibitory concentration: 24800 nM
Beside the measured number, compound 3's estimate is 2.5-fold (0.39 log units) below it; the measured number falls inside the stated range.
By their numbers in this assay, from the lowest: compound 2; then compounds 3 and 1 (each within the scatter of the next).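

In this assay, among the compounds shown here, hydroxycarbamoyl in place of (methylcarbamoyl)methyl on a saturated chain carbon, six bonds along the chain from an aromatic nitrogen, gives a 3.1-fold higher number from compound 2 to compound 3 (0.49 log units; beyond the scatter) on one shared core, a reading of this change that the earlier compounds, with their differing cores, could not give. The chain end at this position therefore does register in this read-out, and the (methylcarbamoyl)methyl end carries the lower number. Nothing at hand accounts for the step.

From the compounds shown here alone, whether a carboxylic acid at this chain end would follow hydroxycarbamoyl remains open. So does the effect of a longer chain on this core.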